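Lengthening the Ethylamino Chain of Compound 3

The compounds below may be only part of what the source reports. "The series", "measured", "known", "first", "only" and "open" are said of these compounds alone.

In an ADME assay on the whole organism for inhibition, with Echinochloa crus-galli var. formosensis as the target, with a stated time of 4 days (a lower number here means a stronger inhibitor, a higher number a weaker inhibitor), compound 1 (`CNc1nc(Cl)nc(N[C@@H](C)c2ccccc2)n1`) gives 26900 nM and compound 2 (`CCNc1nc(Cl)nc(N[C@@H](C)c2ccccc2)n1`) gives 30900 nM. Compound 3 (`CCNc1nc(Cl)nc(N[C@H](C)c2ccccc2)n1`) stands lowest of the three at 2690 nM. The next structure, compound 4 (`CC[C@H](C)Nc1nc(Cl)nc(N[C@H](C)c2ccccc2)n1`), has ethyl in place of hydrogen on a saturated chain carbon bound to a nitrogen on an aromatic ring and a saturated chain carbon, so that ethylamino becomes (sec-butyl)amino: ethyl in place of hydrogen on a saturated chain carbon bound to a nitrogen on an aromatic ring and a saturated chain carbon. Among the measured compounds shown here, the closest precedent is a 1.1-fold higher number from compound 1 to compound 2 (0.06 log units; within the scatter), a methyl-for-hydrogen change in the same chain that lies within the scatter, though it was seen only with the S configuration. The other measured step, an 11-fold lower number from compound 2 to compound 3 (1.06 log units; beyond the scatter), is large and comes with the fact that compounds 2 and 3 differ only in the configuration as drawn. Configuration can therefore matter in this assay, and no measurement covers the one drawn in the new sec-butyl group. No shift beyond the scatter is expected, and the expected change is a 1.2-fold lower number from compound 3 to compound 4 (0.09 log units; within the scatter). Compound 4 is estimated at 2200 nM, with an expected range of 650 nM to 7500 nM.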

Compound 4, half-maximal inhibitory concentration: 52500 nM
Compound 4: the middle estimate sits 24-fold (1.38 log units) below what was measured, and the stated range ends below it.
By their numbers in this assay, from the lowest: compound 3; then compounds 1, 2 and 4 (each within the scatter of the next).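

Changing ethylamino to (sec-butyl)amino is not a neutral change in this assay: it gives a 20-fold higher number from compound 3 to compound 4 (1.29 log units; beyond the scatter). Among the compounds shown here, this is the first step beyond the scatter to come from adding carbon, since the earlier methyl-for-hydrogen step, at a chain carbon bound to the nitrogen alone, gave a 1.1-fold higher number from compound 1 to compound 2 (0.06 log units; within the scatter). Until now, the only large step among these compounds had come with a difference of another kind: the fact that compounds 2 and 3 differ only in the configuration as drawn.

The compounds shown do not separate the effect of the added ethyl from that of the configuration drawn in the new sec-butyl group. They also leave open how an isopropylamino or an n-butylamino group would read at this place in this assay.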